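Ester in place of ether on the imidazopyridine side chain

A few compounds are considered here, and "the series" means these few. Any claim that something is new, unique, unknown or untested is made for them only; others in the source may bear on it.

Of the compounds shown here, two of a shared core have been tested in a functional assay on the whole organism with Rattus norvegicus as the target, with a stated time of 4 h, at a dose of 40 mg/kg by the intraperitoneal route; a lower number here means less inhibition, a higher number more inhibition at the dose given (going by the name of the read-out). Compound 1, `Cc1nc2c(COc3ccccc3)cccn2c1C`, gives 48% in this assay. Compound 2, `COCc1c(C)nc2c(OCc3ccccc3)cccn12`, gives 99% in this assay, the higher of the two numbers, and its distance from compound 1 lies beyond the usual scatter of repeated measurements. Among the compounds with values here, no pair of these two differs in only one place, so no single step between them can be read.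

Compound 3, `COC(=O)Cc1c(C)nc2c(OCc3ccccc3)cccn12`, has not yet been measured in this assay. It differs from compound 2 in one place: methoxycarbonyl in place of methoxy on a saturated chain carbon bound to an aromatic carbon. Methoxycarbonyl brings more heavy atoms and one more hydrogen-bond acceptor than the methoxy it replaces, on the saturated chain carbon bound to an aromatic carbon.

Nothing measured here tells how this assay answers such a change, so the expectation rests on compound 2 alone. Compound 2 already sits near the top of what a percentage of inhibition can show, which leaves little room upward. The expected step from compound 2 to compound 3 in this assay is a number 19 percentage points lower from compound 2 to compound 3 (beyond the scatter), a modest move downward. Compound 3 is therefore estimated at 80%, with a range from 50% to 99%.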

Compound 3, a percentage reported as inhibition, in the whole organism at one dose (the size of the read-out at that dose, not a potency): 23%
Estimate against measurement, compound 3: 57 percentage points above, outside the stated range (below it).
By their numbers in this assay, from the lowest: compound 3; then compound 1; then compound 2.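

In this assay, methoxycarbonyl in place of methoxy on a saturated chain carbon bound to an aromatic carbon gives a number 76 percentage points lower from compound 2 to compound 3 (beyond the scatter), and this is the first change at a single place that can be read among these compounds. It shows that the high number of compound 2 does not come from the shared core and the rest of the molecule alone, for compound 3 keeps all of these and still loses most of the inhibition. The read-out at this place therefore depends strongly on the group carried by that chain carbon, though this rests on one pair, and nothing measured here gives a reason for the drop.

On these data alone, what this assay would show with a carboxylic acid, a primary amide or a hydroxyl group on that chain carbon remains open, and so does whether the carbonyl or the ester as a whole goes with the loss. Also open, as far as these compounds go, is whether a longer chain ending in methoxy would hold the number of compound 2 or follow compound 3 downward.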